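The source may report more compounds than this note shows. Statements on the series, on what has been measured and on what is new or still open speak of the compounds shown alone.

Measured in a functional assay on KB cells (Homo sapiens) for cytotoxicity; a lower number here means that less compound is needed, a higher number that more compound is needed for the effect:

- compound 1 `CCC[C@@H](OC(C)=O)C1=C(Br)[C@@](C)(OC)OC1=O`: 5.4 ug/mL
- compound 2 `CCCCC1=C(Br)C(OC)(C(Br)Br)OC1=O`: 7.6 ug/mL
- compound 3 `CCCCC1=C(Br)C(=C(Br)Br)OC1=O`: only a limit, > 20 ug/mL

Compound 1 holds the lowest of the two numbers shown; compound 2 is its nearest neighbour and lies within the scatter of it, so no order is read between the two. Compound 3 sits at the limit of this assay and gives no number (the limit of > 20 ug/mL in this assay, at which 1 of the 3 values shown sits).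

Compound 4 `CCC[C@@H](OC(C)=O)C1=C(Br)[C@](OC)(C(Br)Br)OC1=O` differs from compound 1 in one place: dibromomethyl in place of methyl on a saturated ring carbon. Among the compounds with values here, no pair of measured compounds differs in exactly this way. Compound 2 also carries a dibromomethyl on the saturated ring carbon, and its value of 7.6 ug/mL lies within the scatter of compound 1, so the change is not expected to move the number far. The step of a 1.2-fold higher number from compound 1 to compound 4 (0.08 log units; within the scatter) in this assay is expected to fall within the scatter, with no clear direction. Compound 4 is therefore estimated at 6.5 ug/mL, within a range from 3 ug/mL to 14 ug/mL.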

Compound 4, concentration for half-maximal effect: 6.1 ug/mL
Beside the measured number, compound 4's estimate is 1.1-fold (0.03 log units) above it; measured number inside the range.
By their numbers in this assay, from the lowest: compounds 1, 4 and 2 (each within the scatter of the next). At a limit, above all of these: compound 3.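

In this assay, dibromomethyl in place of methyl on the saturated ring carbon next to the ring oxygen gives a 1.1-fold higher number from compound 1 to compound 4 (0.05 log units; within the scatter) and leaves the two compounds indistinguishable. Within the data shown here, compound 2 also carries dibromomethyl but differs from compound 1 in more than this one place, so compound 1 and compound 4 are the first pair to isolate the exchange, and on the core of compound 1 the number at this position does not separate methyl from dibromomethyl. No measurement shown gives a cause for this result.

Open, as far as these compounds go, is whether other groups on this carbon, such as a longer chain, an amine or a carboxylic acid, would also leave the number within the scatter. Also open, from the compounds shown here alone, is whether the same exchange reads alike on a different core.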